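Shortening the Amine-Bearing Chain of Compound 2

The source may hold more compounds than are shown below. What is called first, only, known or untested is meant among the compounds shown, and "the series" means these compounds.

Compound 2 `CN(C)CCCNc1nc(-c2ccc(NC(=O)Nc3ccccc3Cl)cc2)nc2c(Cl)c(Cl)sc12` was tested in a functional assay on MKN-45 cells (Homo sapiens) for cytotoxicity, read by MTT assay, with a stated time of 72 h (on this read-out higher numbers stand for weaker inhibition and lower numbers for stronger inhibition), where compound 2 gives 1330 nM. Within the data shown here, its closest measured neighbour is compound 1 `CN(C)CCCNc1nc(-c2ccc(NC(=O)Nc3ccc(Cl)cc3)cc2)nc2c(Cl)c(Cl)sc12`, which in this assay gives 1530 nM; the change a 1.2-fold lower number from compound 1 to compound 2 (0.06 log units; within the scatter) is the only measured step, and the two numbers lie within the scatter of each other, so no order between them can be read. Compound 3 `CN(C)CCNc1nc(-c2ccc(NC(=O)Nc3ccccc3Cl)cc2)nc2c(Cl)c(Cl)sc12` is not yet measured; it differs from compound 2 by dimethylamino in place of (dimethylamino)methyl on a saturated chain carbon, two bonds along the chain from a nitrogen on an aromatic ring. Among the measured compounds shown here, none of the measured steps touches this part of the molecule: the single step concerns the chlorophenyl, not the chain. For the measured compounds named here, with no step bearing on the change, the step of a 1.0-fold lower number from compound 2 to compound 3 (0.01 log units; within the scatter) is expected to stay within the scatter. Compound 3 is therefore estimated to give 1300 nM in this assay, with a range from 500 nM to 3500 nM.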

Compound 3, half-maximal inhibitory concentration: 1170 nM
The estimate for compound 3 lay 1.1-fold (0.05 log units) above the measured number; the measured number falls inside the stated range.
By their numbers in this assay, from the lowest: compounds 3, 2 and 1 (each within the scatter of the next).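

Among these compounds, this is the first measured change to the amine-bearing chain: in this assay, 2-(dimethylamino)ethyl in place of 3-(dimethylamino)propyl gives a 1.1-fold lower number from compound 2 to compound 3 (0.06 log units; within the scatter), so the two numbers cannot be told apart. With the 2-chlorophenyl group held fixed, this shortening of the chain therefore leaves no readable mark on the cytotoxicity read-out, just as the earlier move of the chlorine gave none. Nothing measured on these compounds speaks to why the number holds at this position.

As far as these compounds go, it remains open whether the same holds for the 4-chlorophenyl urea of compound 1, which appears here only with the 3-(dimethylamino)propyl chain. Also open, from the compounds shown here alone, is how this assay would respond to a longer chain such as 4-(dimethylamino)butyl, or to a terminal morpholine or primary amine in place of dimethylamino.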